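The source may report more compounds than this note shows. Statements on the series, on what has been measured and on what is new or still open speak of the compounds shown alone.

Three compounds have been measured in a functional assay on HL-60 cells (Homo sapiens) for cytotoxicity, read by luminescence and CellTiter-Glo, with a stated time of 3 days (a lower number here means a stronger inhibitor, a higher number a weaker inhibitor), so far:

compound 1 `O=C(Nc1ccc(C(F)(F)F)cc1)c1cc(Cl)c(-c2ccccc2)cc1O` (value 490 nM)
compound 2 `N#Cc1ccc(NC(=O)c2cc(Cl)ccc2O)cc1` (value 700 nM)
compound 3 `N#Cc1ccc(NC(=O)c2ccc(-c3ccccc3)cc2O)cc1` (value 700 nM)

In this assay compound 3 gives 700 nM and thus stands level with compound 2 at the digits shown, and all three values lie within the usual scatter of one another. Compound 4 `N#Cc1ccc(NC(=O)c2cc(Cl)c(-c3ccccc3)cc2O)cc1` has not yet been measured. It differs from compound 3 by chloro in place of hydrogen on an aromatic carbon, ortho to a phenyl group and para to a hydroxy group (chloro in place of hydrogen on an aromatic carbon). Among the measured compounds shown here, no measured pair isolates this change. Chloro and phenyl occur together in compound 1 (490 nM), which carries trifluoromethyl where compound 4 carries nitrile. The closest evidence therefore points to little movement: in this assay a small step towards a lower number is expected, not beyond the scatter. The expected step is a 1.4-fold lower number from compound 3 to compound 4 (0.15 log units; within the scatter) in this estimate. Compound 4 is estimated at 500 nM (expected range 200 nM to 1200 nM).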

Compound 4, half-maximal inhibitory concentration: 520 nM
Compound 4: middle estimate off by 1.0-fold (0.02 log units), on the low side; the range from low to high includes it.
By their numbers in this assay, from the lowest: compounds 1, 4, 2 and 3 (each within the scatter of the next).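

In this assay, chloro in place of hydrogen on the aromatic carbon ortho to a phenyl group and para to a hydroxy group gives a step within the scatter, a 1.3-fold lower number from compound 3 to compound 4 (0.13 log units; within the scatter), so with the phenyl group present this position tolerates the change without a clear shift. The two other single changes also stay within the scatter: phenyl in place of hydrogen gives a 1.3-fold lower number from compound 2 to compound 4 (0.13 log units; within the scatter), and cyano in place of trifluoromethyl gives a 1.1-fold higher number from compound 1 to compound 4 (0.03 log units; within the scatter). No independent measurement is available to explain these results.

The compounds shown carry only hydrogen or chloro at this position, so it remains open whether an amine or a methoxy group there would give a step beyond the scatter. From the compounds shown here alone, what a carboxylic acid on the phenyl group would do also remains open.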